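This account rests on a few compounds, and the source may have more. Where it says the series, first, only, none or still open, it means among the compounds named here.

Measured in an ADME assay on SH-SY5Y cells (Homo sapiens) for cytotoxicity, read by MTT assay, with a stated time of 72 h; a lower number here means a stronger inhibitor, a higher number a weaker inhibitor:
- compound 1 `O=C(CN1CCN(C(=O)c2ccc(Br)cc2)CC1)N1CCN(CCCc2c[nH]c3ccccc23)CC1` gives 59300 nM
- compound 2 `COc1ccc2[nH]cc(CCCN3CCN(C(=O)CN4CCN(C(=O)c5ccc(Cl)cc5)CC4)CC3)c2c1` gives 159000 nM
- compound 3 `COc1ccc(C(=O)N2CCN(CC(=O)N3CCN(CCCc4c[nH]c5ccc(OC)cc45)CC3)CC2)cc1` gives 190000 nM

Compound 3 lies within the scatter of compound 2. Compound 3 at 190000 nM is clearly a higher number than compound 1 at 59300 nM in this assay.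

Next comes compound 4 `COc1ccc2[nH]cc(CCCN3CCN(C(=O)CN4CCN(C(=O)c5ccc(Br)cc5)CC4)CC3)c2c1`, with bromo in place of methoxy on an aromatic carbon, para to a large group: bromo in place of methoxy on an aromatic carbon. The same difference reads 4-methoxyphenyl to 4-bromophenyl.

Among the measured compounds shown here, the one measured step at this place is a 1.2-fold higher number from compound 2 to compound 3 (0.08 log units; within the scatter), with methoxy in place of chloro, and it stays within the scatter. Compound 1 also holds the 4-bromophenyl group, and its 59300 nM leaves some room toward lower numbers. For the measured compounds named here, only a single step bears on this change, so the evidence is thin.

No step beyond the scatter is expected in this assay. The expected step is a 1.4-fold lower number from compound 3 to compound 4 (0.13 log units; within the scatter). The estimate for compound 4 is 140000 nM, with an expected range from 70000 nM to 280000 nM.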

Compound 4, half-maximal inhibitory concentration: 150000 nM
For compound 4 the middle estimate is 1.1-fold (0.03 log units) below the measured one, and the stated range covers the measured number.
By their numbers in this assay, from the lowest: compound 1; then compounds 4, 2 and 3 (each within the scatter of the next).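

In this assay, bromo joins chloro and methoxy on the same aromatic carbon, para to a large group, and the three are not separated: bromo in place of methoxy gives a 1.3-fold lower number from compound 3 to compound 4 (0.10 log units; within the scatter), and bromo in place of chloro gives a 1.1-fold lower number from compound 2 to compound 4 (0.03 log units; within the scatter). Among the compounds shown here, the only step here beyond the scatter comes from the other site of change, where, with the 4-bromophenyl group held fixed, a hydrogen gives way to a methoxy group and the result is a 2.5-fold higher number from compound 1 to compound 4 (0.40 log units; beyond the scatter), a modest step resting on this one pair. No supporting measurement accounts for any of these steps.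

Still open, going by these compounds, is whether an amine or a carboxylic acid in place of bromo on that aromatic carbon would give a step beyond the scatter. Also open, on these data alone, is whether the methoxy-for-hydrogen step holds with 4-methoxyphenyl or a chloro group in place of the 4-bromophenyl group.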